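Methoxy for Methyl on the Biaryl Amide Tail

This account rests on a few compounds, and the source may have more. Where it says the series, first, only, none or still open, it means among the compounds named here.

Compound 1 `COc1ccc(-c2ccc(C(=O)Nc3ccc(Oc4ccnc5[nH]ccc45)cc3)nc2)cc1` gives > 10000 nM in a functional assay on PC-3 cells (Homo sapiens) for cytotoxicity, read by MTT assay, with a stated time of 72 h (a higher number here means a weaker inhibitor, a lower number a stronger inhibitor), a limit of the assay rather than a number (the limit of > 10000 nM in this assay, at which 1 of the 3 values shown sits). Compound 2 `O=C(Nc1ccc(Oc2ccnc3[nH]ccc23)c(F)c1)c1ccc(-c2ccccc2)cn1` gives 760 nM in this assay. Compound 3 `Cc1ccc(-c2ccc(C(=O)Nc3ccc(Oc4ccnc5[nH]ccc45)c(F)c3)nc2)cc1` gives 2640 nM in this assay.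

Among the two numbers shown, compound 3 stands highest; the step of a 3.5-fold higher number from compound 2 to compound 3 (0.54 log units; beyond the scatter) is the only measured one that bears on the tail. Compound 4 `COc1ccc(-c2ccc(C(=O)Nc3ccc(Oc4ccnc5[nH]ccc45)c(F)c3)nc2)cc1` differs from compound 3 by methoxy in place of methyl on an aromatic carbon. The change from hydrogen to methyl already raised the number, and compound 1, which carries methoxy without the fluorine, reached only the limit. A further, modest rise is therefore expected for compound 4 as a 2.3-fold higher number from compound 3 to compound 4 (0.36 log units; beyond the scatter). Compound 4 is estimated at 6000 nM, between 2000 nM and 18000 nM.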

Compound 4, half-maximal inhibitory concentration: 650 nM
The estimate for compound 4 lay 9.2-fold (0.97 log units) above the measured number; the whole stated range lies above it.
By their numbers in this assay, from the lowest: compounds 4 and 2 (each within the scatter of the next); then compound 3. At a limit, above all of these: compound 1.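

In this assay, the change from 4-methylphenyl to 4-methoxyphenyl gives a 4.1-fold lower number from compound 3 to compound 4 (0.61 log units; beyond the scatter), so the rise seen with methyl does not carry over to methoxy at this position, and a 1.2-fold lower number from compound 2 to compound 4 (0.07 log units; within the scatter) leaves the methoxy and unsubstituted tails level. With the methoxy tail held, fluoro in place of hydrogen on the core gives an at least 15-fold lower number from compound 1 to compound 4 (1.18 log units; beyond the scatter). The starting value of that step is a limit, that of compound 1: the limit of > 10000 nM in this assay, at which 1 of the 4 values shown sits.

As far as these compounds go, how a hydroxyl, an ethoxy or an amine would read at this position stays open. So does the size of the fluoro step on the methyl tail.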